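This account rests on a few compounds, and the source may have more. Where it says the series, first, only, none or still open, it means among the compounds named here.

Measured compounds:
Compound 1, `COc1ccc(-c2c(Br)c(=O)c3c(OC)cc(OC)cc3n2S(=O)(=O)c2ccc(OC)cc2)cc1`, in a functional assay on SUP-B15 cells (Homo sapiens) for antiproliferative activity, with a stated time of 72 h (a higher number here means that more compound is needed for the effect, a lower number that less compound is needed), compound 1 gives 2920 nM.
Compound 2, `COc1ccc(-c2cc(=O)c3c(OC)cc(OC)cc3n2S(=O)(=O)c2ccc(C#N)cc2)cc1`, in this assay compound 2 gives 7900 nM.

Among the two measured compounds, compound 2 has the highest number in this assay. For the measured compounds named here, its nearest neighbour is compound 1, whose number is lower by an amount that lies beyond the usual scatter; the two compounds differ in more than one place, so no single step connects them, and only their two values can be compared.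

Compound 3, `COc1ccc(-c2cc(=O)c3c(OC)cc(OC)cc3n2S(=O)(=O)c2ccc(Br)cc2)cc1`, has not yet been measured in this assay. It differs from compound 2 in one place: bromo in place of cyano on an aromatic carbon. Going by the values given here, no pair of measured compounds shows this exchange, so there is no measured step on which to lean. The author expects a small step from compound 2 to compound 3 in this assay, a 1.6-fold lower number from compound 2 to compound 3 (0.20 log units; within the scatter), pointing toward a somewhat lower number but not clearly beyond the scatter. For compound 3 in this assay the author estimates 5000 nM, with a plausible range from 1500 nM to 16000 nM.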

Compound 3, half-maximal effective concentration: 63800 nM
For compound 3 the middle estimate is 13-fold (1.11 log units) below the measured one, and the stated range ends below it.
By their numbers in this assay, from the lowest: compound 1; then compound 2; then compound 3.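

For the compounds shown here, the single exchange of (4-cyanophenyl)sulfonyl to (4-bromophenyl)sulfonyl gives, in this assay, an 8.1-fold higher number from compound 2 to compound 3 (0.91 log units; beyond the scatter), so the group on this aromatic carbon, para to a large group, clearly affects the antiproliferative read-out. Going by these compounds alone, compound 1 and compound 2 differ in more than one place and could not show this; this step is the first to tie a change beyond the scatter to one position, and here cyano is the better of the two groups. Nothing measured on these compounds explains why the two groups part so widely.

From the compounds shown here alone, with only cyano and bromo compared at this position on the shared core, it remains open how an amine, a carboxylic acid or a fluoro group there would compare, and so whether the values at this position follow any order. Going by these compounds, it is also open whether the same exchange would give a step of similar size on a compound carrying the bromo group of compound 1 on the core.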